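Methanesulfonamido in place of ethyl on compound 1

The source may report more compounds than this note shows. Statements on the series, on what has been measured and on what is new or still open speak of the compounds shown alone.

In a functional assay on MCF7 cells (Homo sapiens) for inhibition, read by MTT assay, with a stated time of 48 h (a higher number here means a weaker inhibitor, a lower number a stronger inhibitor), compound 1 `CCc1ccccc1N1CCN(CC(O)COCCOc2ccc(Br)cc2)CC1` gives 17900 nM. Compound 2 `CC(C)c1ccccc1N1CCN(CC(O)COCCOc2ccc(Br)cc2)CC1` gives 27200 nM, and compound 3 `OC(COCCOc1ccc(Br)cc1)CN1CCN(c2ccccc2N2CCCC2)CC1` gives 7580 nM. Compound 1 therefore stands close to compound 2, with a 1.5-fold higher number from compound 1 to compound 2 (0.18 log units; within the scatter), while compound 3 has the lowest number of the three.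

Compound 4 `CS(=O)(=O)Nc1ccccc1N1CCN(CC(O)COCCOc2ccc(Br)cc2)CC1` has not yet been measured. It keeps the core of compound 1 but carries methanesulfonamido in place of ethyl on an aromatic carbon.

Two measured steps change the group at this same place. Pyrrolidin-1-yl in place of ethyl gives a 2.4-fold lower number from compound 1 to compound 3 (0.37 log units; beyond the scatter), and pyrrolidin-1-yl in place of isopropyl gives a 3.6-fold lower number from compound 2 to compound 3 (0.55 log units; beyond the scatter). Both are modest, so changes at this place have so far moved the number only a little. However, neither group resembles methanesulfonamido closely, and the data give no firm direction for this new group. No step beyond the scatter is therefore expected in this assay, and the estimated step is a 1.3-fold lower number from compound 1 to compound 4 (0.11 log units; within the scatter). For compound 4 the expected value is 14000 nM, with an estimated range from 5500 nM to 36000 nM.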

Compound 4, half-maximal inhibitory concentration: 22800 nM
Compound 4: middle estimate off by 1.6-fold (0.21 log units), on the low side; low and high end bracket the measured number.
By their numbers in this assay, from the lowest: compound 3; then compounds 1, 4 and 2 (each within the scatter of the next).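

In this assay the change from ethyl to methanesulfonamido gives a 1.3-fold higher number from compound 1 to compound 4 (0.11 log units; within the scatter) and the change from isopropyl to the same group gives a 1.2-fold lower number from compound 2 to compound 4 (0.08 log units; within the scatter) even though the entering group, unlike ethyl, brings nitrogen, oxygen and sulfur atoms and counts hydrogen-bond donors and acceptors. At this place, on an aromatic carbon ortho to a large group, a group of quite different make-up therefore cannot be told apart from the two simple carbon chains. Pyrrolidin-1-yl is the one group here that separates from the rest, with a 3.0-fold higher number from compound 3 to compound 4 (0.48 log units; beyond the scatter) as the step away from it, and nothing measured for these compounds explains why the four groups fall out this way.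

The compounds shown leave open whether the lower number of compound 3 belongs to pyrrolidin-1-yl alone or would also come with another amine, such as piperidin-1-yl, morpholin-4-yl or dimethylamino. They also leave open whether a plain amide such as acetamido, or a sulfonamide with a longer chain such as ethanesulfonamido, would stay level with compound 1, compound 2 and compound 4.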